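The source may report more compounds than this note shows. Statements on the series, on what has been measured and on what is new or still open speak of the compounds shown alone.

Going by the values given here, compound 2 `CCCCCOC(=O)N1CCN(C(=O)c2nc(Nc3cc(C4CC4)[nH]n3)c3cc(Cl)ccc3n2)C[C@H]1C` gives 99.8% in a physicochemical assay, read by HPLC, in phosphate buffer, with a stated time of 2 h, at pH 7.4 (on this read-out lower numbers stand for a less stable compound and higher numbers for a more stable compound), the larger of the two numbers measured so far, although the gap to the only other compound lies within the scatter. That other compound is compound 1 `CC(OC(=O)N1CCN(C(=O)c2nc(Nc3cc(C4CC4)[nH]n3)c3cc(Cl)ccc3n2)C[C@H]1C)OC(=O)C(C)(C)C`, which in this assay gives 90.5%; the step of a number 9.3 percentage points higher from compound 1 to compound 2 (within the scatter) is within the scatter. Compound 3 `CC(OC(=O)C(C)C)OC(=O)N1CCN(C(=O)c2nc(Nc3cc(C4CC4)[nH]n3)c3cc(Cl)ccc3n2)C[C@H]1C` has not yet been measured in this assay. It differs from compound 2 in one place: 1-((isopropylcarbonyl)oxy)ethyl in place of pentyl on an oxygen next to a carbonyl group. Among the compounds with values here, the only measured step that bears on this change is the one in which 1-(((tert-butyl)carbonyl)oxy)ethyl was exchanged for pentyl on an oxygen next to a carbonyl group, moving the number by a number 9.3 percentage points higher from compound 1 to compound 2 (within the scatter), within the scatter. Compound 3 puts a group of the same kind, 1-((isopropylcarbonyl)oxy)ethyl, back onto that oxygen, so the step is expected to run in the opposite direction and to stay small, a number 8.8 percentage points lower from compound 2 to compound 3 (within the scatter), with no change beyond the scatter. Compound 3 is therefore estimated to give 91% in this assay, within a range from 78% to 99.5%.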

Compound 3, percent of the compound remaining: 96.6%
Compound 3: middle estimate off by 5.6 percentage points, on the low side; low and high end bracket the measured number.
By their numbers in this assay, from the lowest: compounds 1, 3 and 2 (each within the scatter of the next).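

In this assay, 1-((isopropylcarbonyl)oxy)ethyl in place of pentyl on an oxygen next to a carbonyl group gives a number 3.2 percentage points lower from compound 2 to compound 3 (within the scatter), so a second group of this kind also cannot be told apart from the plain pentyl chain, even though it adds an ester carbonyl and has more heavy atoms. The exchange between the two groups of this kind can now be read directly: hydrogen in place of one methyl of the tert-butyl end gives a number 6.1 percentage points higher from compound 1 to compound 3 (within the scatter), so this small trim at the far end of the group produces no change that can be told from scatter, and compounds 1, 2 and 3 form a single group in this read-out. No measurement here explains why these numbers fall as they do.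

The three compounds leave open whether a much different group on this oxygen, such as a chain ending in an amine or a carboxylic acid, would move the number beyond the scatter. They also leave open what happens with (isopropylcarbonyl)oxymethyl, which lacks the methyl on the carbon bound to that oxygen, or with a benzyl group there.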